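From 1-carboxy-2-methylpropyl to 2-carboxyethyl in compound 2

This account rests on a few compounds, and the source may have more. Where it says the series, first, only, none or still open, it means among the compounds named here.

Measured in a functional assay on MCF7 cells (Homo sapiens) for antiproliferative activity, read by MTT assay, with a stated time of 72 h; on this read-out higher numbers stand for weaker inhibition and lower numbers for stronger inhibition:
Compound 1 `CCCCC(=O)c1ccc(C(CC)(CC)c2ccc(C#CC(O)(CC)CC)c(C)c2)n1CC`: > 50000 nM
Compound 2 `CCn1c(C(=O)N[C@H](C(=O)O)C(C)C)ccc1C(CC)(CC)c1ccc(C#CC(O)(CC)CC)c(C)c1`: 13000 nM

Compound 1 sits at a limit of the assay: the limit of > 50000 nM in this assay, at which 1 of the 2 values shown sits. Within the data shown here, compound 2, at 13000 nM, holds the only actual number in this assay. Compound 3 `CCn1c(C(=O)NCCC(=O)O)ccc1C(CC)(CC)c1ccc(C#CC(O)(CC)CC)c(C)c1` keeps the shared core and changes one group: 2-carboxyethyl in place of 1-carboxy-2-methylpropyl on an amide-type nitrogen. Among the measured compounds shown here, the one measured step, an at least 3.8-fold lower number from compound 1 to compound 2 (0.58 log units; beyond the scatter), brought in the (1-carboxy-2-methylpropyl)amino group and rests on that limit. Compound 3 still carries a carboxy-bearing chain on the amide-type nitrogen, so a step beyond the scatter is not expected. The estimated step is a 1.4-fold higher number from compound 2 to compound 3 (0.14 log units; within the scatter). For compound 3 the expected value is 18000 nM, with an estimated range of 7000 nM to 45000 nM.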

Compound 3, half-maximal inhibitory concentration: > 50000 nM
Compound 3 ended at the assay's limit (the forecaster's own chance of this, stated with the estimate: 25%); middle value at least 2.7-fold (0.44 log units) from the limit.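

In this assay, keeping a carboxy-bearing chain on the amide-type nitrogen did not hold the activity of compound 2: 2-carboxyethyl in place of 1-carboxy-2-methylpropyl gave an at least 3.8-fold higher number from compound 2 to compound 3 (0.58 log units; beyond the scatter). Compound 3 gives > 50000 nM, a limit of the assay and not a number. The step between compound 1 and compound 3 therefore cannot be read, and compound 2 alone keeps an actual number: the limit of > 50000 nM in this assay, at which 2 of the 3 values shown sit.

The compounds shown do not separate the loss of the defined stereocentre from the shortening of the chain. As far as these compounds go, how 1-carboxyethyl, which would keep a stereocentre on a shorter chain, would read also stays open.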